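This account rests on a few compounds, and the source may have more. Where it says the series, first, only, none or still open, it means among the compounds named here.

Measured compounds:

Compound 1, `CC(C)CN(Cc1ccc(C(=O)NO)cc1)S(=O)(=O)c1cc(F)c(F)c(F)c1F`. In an assay on Sf9 cells for inhibition of histone deacetylase 11 (Homo sapiens), read by fluorescence and mobility shift assay (on this read-out higher numbers stand for weaker inhibition and lower numbers for stronger inhibition), compound 1 gives > 1000 nM, which is a limit of the assay and not a number.

Compound 2, `COCCN(Cc1ccc(C(=O)NO)cc1)S(=O)(=O)c1cc(F)c(F)c(F)c1F`. In this assay compound 2 gives > 1000 nM, again a limit rather than a number.

Compound 3, `COc1cc(C(=O)NO)ccc1CN(C(C)C)S(=O)(=O)c1cc(F)c(F)c(F)c1F`. In this assay compound 3 gives > 1000 nM, also a limit and not a number.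

Compound 3 therefore stands at the limit of this assay, and the same is true of every other compound measured here, as the limit of > 1000 nM in this assay, at which 3 of the 3 values shown sit, shows. No ranking among the three can be read from such values. Within the data shown here, the one step that can be written between measured compounds, a step that the two limits leave unreadable from compound 1 to compound 2, shows this directly: two limits say nothing about how far apart the compounds lie.

The unmeasured compound 4, `CC(C)N(Cc1ccc(C(=O)NO)cc1)S(=O)(=O)c1cc(F)c(F)c(F)c1F`, differs from compound 3 by hydrogen in place of methoxy on an aromatic carbon. Among the measured compounds shown here, no measured step touches this place, so there is no direct precedent for it. Since every value shown sits at the limit, the expectation for compound 4 is simply that it lands near the same limit, with no readable step in either direction. The expected value for compound 4 is 1500 nM, with a range from 500 nM to 5000 nM, and this estimate corresponds to a step that the limit leaves unreadable from compound 3 to compound 4.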

Compound 4, half-maximal inhibitory concentration: > 1000 nM
Compound 4: no number, only a limit (the forecaster's own chance of this, stated with the estimate: 75%); the middle value is on the limit's open side.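

In this assay compound 4 gives > 1000 nM as a limit and not a number. Among these compounds, no step from compound 1, compound 2 or compound 3 to compound 4 can be read, because every value stands at the same limit: the limit of > 1000 nM in this assay, at which 4 of the 4 values shown sit. Going by these compounds, how strongly each of these four compounds inhibits the enzyme, and how they rank, remains open.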